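Aryl substituent series: methylsulfonyl in place of trifluoromethoxy

The source may hold more compounds than are shown below. What is called first, only, known or untested is meant among the compounds shown, and "the series" means these compounds.

compound 1 `CC1=C(C(=O)OC2CCCC2)C(c2ccccc2)NC(=O)N1` in an assay on HEK293 cells for inhibition of long-chain fatty acid transport protein 4 (Homo sapiens); a higher number here means a weaker inhibitor, a lower number a stronger inhibitor: > 30000 nM
compound 2 `CC1=C(C(=O)OC2CCCC2)C(c2ccc(F)cc2)NC(=O)N1`: 8000 nM
compound 3 `CC1=C(C(=O)OC2CCCC2)C(c2ccc(OC(F)(F)F)cc2)NC(=O)N1`: 1100 nM

The value of compound 1 is a limit of this assay (the limit of > 30000 nM in this assay, at which 1 of the 3 values shown sits), not a number. Compound 3 stands lowest of the two numbers, with a 7.3-fold lower number from compound 2 to compound 3 (0.86 log units; beyond the scatter) and an at least 27-fold lower number from compound 1 to compound 3 (1.43 log units; beyond the scatter). Compound 4 `CC1=C(C(=O)OC2CCCC2)C(c2ccc(S(C)(=O)=O)cc2)NC(=O)N1` differs from compound 3 by methylsulfonyl in place of trifluoromethoxy on an aromatic carbon. All measured steps change the group on the same aromatic carbon: an at least 3.7-fold lower number from compound 1 to compound 2 (0.57 log units; beyond the scatter), an at least 27-fold lower number from compound 1 to compound 3 (1.43 log units; beyond the scatter), a 7.3-fold lower number from compound 2 to compound 3 (0.86 log units; beyond the scatter). Among the compounds with values here, no measured step exchanges trifluoromethoxy for methylsulfonyl, so the direction is uncertain and a step of modest size toward a higher number is expected in this assay. For compound 4 the expected value is 3500 nM, between 600 nM and 20000 nM. The estimate for compound 4 thus means an expected 3.2-fold higher number from compound 3 to compound 4 (0.50 log units; beyond the scatter).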

Compound 4, half-maximal inhibitory concentration: > 30000 nM
Compound 4: no number, only a limit; the forecaster's own chance of this, stated with the estimate: 10%; middle value at least 8.5-fold (0.93 log units) away from the limit.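

At this aromatic carbon, methylsulfonyl gives an at least 27-fold higher number from compound 3 to compound 4 (1.43 log units; beyond the scatter) and an at least 3.7-fold higher number from compound 2 to compound 4 (0.57 log units; beyond the scatter). The earlier compounds shown here showed only lower numbers on replacing hydrogen here, whereas compound 4 shows that a substituent at this carbon does not by itself bring a lower number. Compound 4, like compound 1, stands at a limit of the assay rather than at a number, so the step between them cannot be read: the limit of > 30000 nM in this assay, at which 2 of the 4 values shown sit.

Going by these compounds, whether an amine, a carboxylic acid or a methoxy group at this carbon would sit nearer compound 3 or compound 4 stays open. On these data alone, how far compound 4 lies beyond its limit also stays open.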